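The source may hold more compounds than are shown below. What is called first, only, known or untested is meant among the compounds shown, and "the series" means these compounds.

Compounds measured so far:
compound 1 `COc1ccccc1-c1ccc(N2CC(N3CCN(C(=O)c4ccco4)CC3)CC2=O)cc1` — 30 nM
compound 2 `O=C(c1ccco1)N1CCN(C2CC(=O)N(c3ccc(-c4ccc(F)nc4)cc3)C2)CC1` — 127 nM
compound 3 `COc1ccccc1-c1cccc(N2CC(N3CCN(c4ncccn4)CC3)CC2=O)c1` — 85 nM

All three numbers come from an assay on isolated protein for inhibition of Monoglyceride lipase (Mus musculus), with a stated time of 30 min; a lower number here means a stronger inhibitor, a higher number a weaker inhibitor. Compound 3 stands second highest of the three: against compound 2 it is within the scatter, against compound 1 it is beyond it, compound 1 giving the lowest number of the set.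

Compound 4 `O=C1CC(N2CCN(c3ncccn3)CC2)CN1c1cccc(-c2ccc(F)nc2)c1` is not yet measured. It differs from compound 3 in one place: 6-fluoropyridin-3-yl in place of 2-methoxyphenyl on an aromatic carbon. Going by the values given here, the same exchange, though on a different ring carbon of the shared core and with a different group on the piperazine, is covered by the one measured step, a 4.2-fold higher number from compound 1 to compound 2 (0.63 log units; beyond the scatter). Among the compounds with values here, no second step of this kind exists, so the transfer to the core of compound 3 rests on that single pair.

On that basis a step of similar size and direction is expected for compound 4 in this assay, that is a 3.5-fold higher number from compound 3 to compound 4 (0.55 log units; beyond the scatter) because of a 4.2-fold higher number from compound 1 to compound 2 (0.63 log units; beyond the scatter). The estimated value for compound 4 is 300 nM, with an expected range from 120 nM to 800 nM.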

Compound 4, half-maximal inhibitory concentration: 2100 nM
The estimate for compound 4 lay 7.0-fold (0.85 log units) below the measured number; measured number outside the range, above it.
By their numbers in this assay, from the lowest: compound 1; then compounds 3 and 2 (each within the scatter of the next); then compound 4.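

In this assay, 6-fluoropyridin-3-yl in place of 2-methoxyphenyl gives a 25-fold higher number from compound 3 to compound 4 (1.39 log units; beyond the scatter), so the 2-methoxyphenyl compound has the lower number in both pairs. The exchange keeps its direction across the two cores, but its size does not carry over: the same change on two cores in this assay, a 4.2-fold higher number (0.63 log units; beyond the scatter) from compound 1 to compound 2 and a 25-fold higher number (1.39 log units; beyond the scatter) from compound 3 to compound 4, 5.8-fold (0.77 log units) apart, beyond the scatter of two such steps The penalty for this exchange therefore depends on its context, and a single pair is not a reliable guide to its size on another core.

The two pairs differ both in the ring carbon carrying the exchange and in the group on the piperazine, so the compounds shown cannot say which of these sets the gap. Also open, from the compounds shown here alone, is whether the fluorine or the ring nitrogen drives the loss, which a plain pyridin-3-yl or a 4-fluorophenyl group at this place would separate.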